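Positional shift of the fluorine on the phenyl group

The source may hold more compounds than are shown below. What is called first, only, known or untested is meant among the compounds shown, and "the series" means these compounds.

Compound 1 `Fc1ccc(-c2cn3ccnc3c(-c3ccc4ncn(C5CCCCC5)c4c3)n2)cc1` and compound 2 `Clc1ccc(-c2cn3ccnc3c(-c3ccc4ncn(C5CCCCC5)c4c3)n2)cc1` share one core and differ only in the halogen carried on the phenyl group. In a functional assay on SNB-75 cells (Homo sapiens) for inhibition, read by sulforhodamine B assay, with a stated time of 48 h, tested at 10 uM (a higher number here means more inhibition at the concentration tested (going by the name of the read-out), a lower number less inhibition), compound 1 gives 21%, and compound 2 gives 31.2%. For the measured compounds named here, the single measured step is a number 10.2 percentage points higher from compound 1 to compound 2 (beyond the scatter), so compound 1 stands as the lower of the two numbers, with compound 2 beyond the scatter above it.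

Compound 3 `Fc1ccccc1-c1cn2ccnc2c(-c2ccc3ncn(C4CCCCC4)c3c2)n1` keeps the same atoms joined differently: 2-fluorophenyl in place of 4-fluorophenyl on an aromatic carbon. Going by the values given here, no measured step moves a substituent from one place to another on that phenyl group; the step from compound 1 to compound 2 exchanges one halogen for another and is only modest, so it bears on compound 3 only in showing that the changes tried so far on this phenyl group have shifted the read-out by a small amount. On that basis no step beyond the scatter is expected for compound 3 in this assay, in either direction, a number 1 percentage points higher from compound 1 to compound 3 (within the scatter). The estimate for compound 3 is 22%, with a range of 8% to 38%.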

Compound 3, a percentage reported as inhibition, at one concentration (the size of the read-out at that concentration, not a potency): 29.7%
Beside the measured number, compound 3's estimate is 7.7 percentage points below it; the range from low to high includes it.
By their numbers in this assay, from the lowest: compounds 1, 3 and 2 (each within the scatter of the next, the first and the last beyond it).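

In this assay, for the compounds shown here, the first change of place on this phenyl group, 2-fluorophenyl in place of 4-fluorophenyl with the same atoms, gives a number 8.7 percentage points higher from compound 1 to compound 3 (within the scatter), so the shift of the fluorine alone produces no step that can be separated from the scatter. Going by these compounds alone, the exchange of 4-chlorophenyl for 2-fluorophenyl gives a number 1.5 percentage points lower from compound 2 to compound 3 (within the scatter), so compound 3 cannot be separated from either of the earlier compounds, even though those two lie beyond the scatter of each other, and the series offers no clean ranking of these three phenyl groups. Nothing at hand explains these numbers, and no reason can be offered for them here.

Still open, on these data alone, is whether a phenyl group carrying an amine, a carboxylic acid or a methoxy group in place of the halogen would move the read-out well beyond the scatter, or whether the small steps seen so far hold only among halogens. Each number is also a single read-out at one concentration, so how these compounds compare in potency remains undecided.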